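The source may hold more compounds than are shown below. What is called first, only, known or untested is meant among the compounds shown, and "the series" means these compounds.

Measured so far in a physicochemical assay for solubility; a higher number here means a more soluble compound, a lower number a less soluble compound:
- compound 1 `Cn1nccc1-c1cc(C(F)(F)F)ccc1[C@H]1CCOc2cc(S(=O)(=O)Nc3ccc(F)cn3)ccc21`: 29000 nM
- compound 2 `Cc1nc(-c2cc(C(F)(F)F)ccc2[C@H]2CCOc3cc(S(=O)(=O)Nc4nccs4)ccc32)co1`: 61000 nM

Of these two numbers, compound 1 stands lowest at 29000 nM, and compound 2 gives the higher number, 61000 nM, a gap beyond the usual scatter. Compound 3 `Cn1nccc1-c1cc(C(F)(F)F)ccc1[C@H]1CCOc2cc(S(=O)(=O)Nc3ccncn3)ccc21` keeps the core of compound 1 but carries pyrimidin-4-yl in place of 5-fluoropyridin-2-yl on a sulfonamide nitrogen. For the measured compounds named here, no measured pair isolates this change, so the data offer only a rough guide. Going by the values given here, the two values bracket a narrow span, and compound 2 at 61000 nM marks the only higher reading available. A modest upward move in this assay is therefore expected, with no firm evidence against a result within the scatter. The estimated step is a 1.9-fold higher number from compound 1 to compound 3 (0.28 log units; within the scatter). For compound 3 the expected value is 55000 nM, with an estimated range from 22000 nM to 130000 nM.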

Compound 3, solubility: 1180000 nM
Estimate against measurement, compound 3: 21-fold (1.33 log units) below; measured number above the stated range.
By their numbers in this assay, from the lowest: compound 1; then compound 2; then compound 3.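

In this assay, for the compounds shown here, the pair of compound 1 and compound 3 is the first to differ in one place only, and it shows that the group on a sulfonamide nitrogen is far from a silent position. With the core of compound 1 unchanged, pyrimidin-4-yl in place of 5-fluoropyridin-2-yl goes with a 41-fold higher number from compound 1 to compound 3 (1.61 log units; beyond the scatter) and this large step lies beyond the scatter. Exchanging one six-membered aromatic ring for another at this position is thus enough to move the number strongly, though nothing measured here explains the size of the step.

This single pair cannot separate the removal of the fluorine from the added ring nitrogen, and an unsubstituted pyridin-2-yl or a pyrimidin-2-yl would bear on that. As far as these compounds go, whether the same exchange gives a similar step on another core also remains open.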